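Urea series at Kir3.1/Kir3.2: predicting a chlorophenyl analogue

This account rests on a few compounds, and the source may have more. Where it says the series, first, only, none or still open, it means among the compounds named here.

Three diaryl ureas sharing one core have been measured in an assay on HEK293 cells for activation of Kir3.1/Kir3.2 (Homo sapiens), read by fluorescence and thallium flux, with a stated time of 4 min; on this read-out higher numbers stand for an effect only at larger amounts of compound and lower numbers for an effect already at smaller amounts. Compound 1 `Cc1ccc(NC(=O)Nc2ccccc2)cc1S(=O)(=O)N(C)C` gives 1400 nM; compound 2 `Cc1ccc(NC(=O)Nc2ccc(C)c(S(=O)(=O)N(C)C)c2)cc1Cl` gives 2900 nM; compound 3 `COc1ccc(NC(=O)Nc2ccc(C)c(S(=O)(=O)N(C)C)c2)cc1` gives 1700 nM. Compound 2 has the highest number of the three: its nearest neighbour is compound 3, with a difference that stays within the scatter, while the step of a 2.1-fold higher number from compound 1 to compound 2 (0.32 log units; beyond the scatter) is the only one beyond it.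

Compound 4 `Cc1ccc(NC(=O)Nc2ccccc2Cl)cc1S(=O)(=O)N(C)C` is not yet measured. It differs from compound 2 by 2-chlorophenyl in place of 3-chloro-4-methylphenyl on an amide-type nitrogen. For the measured compounds named here, two measured steps bear on the change. The step of a 2.1-fold higher number from compound 1 to compound 2 (0.32 log units; beyond the scatter) shows that adding the 3-chloro-4-methylphenyl group in place of phenyl raised the number modestly, and the step of a 1.7-fold lower number from compound 2 to compound 3 (0.23 log units; within the scatter) shows that exchanging it for 4-methoxyphenyl lowered it, though within the scatter. Going by the values given here, compound 4 moves away from the 3-chloro-4-methylphenyl group toward a smaller ring, so a lower number than that of compound 2 is expected, although no measured compound carries 2-chlorophenyl and the size of the step is uncertain. For compound 4 the expected step is a 1.6-fold lower number from compound 2 to compound 4 (0.21 log units; within the scatter). The estimate for compound 4 in this assay is 1800 nM, with a range from 700 nM to 4500 nM.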

Compound 4, half-maximal effective concentration: 2700 nM
Compound 4: the middle estimate sits 1.5-fold (0.18 log units) below what was measured; the range from low to high includes it.
By their numbers in this assay, from the lowest: compounds 1, 3, 4 and 2 (each within the scatter of the next, the first and the last beyond it).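

In this assay the group on the amide-type nitrogen is now a ring bearing a chlorine without the methyl, and the step of a 1.1-fold lower number from compound 2 to compound 4 (0.03 log units; within the scatter) stays within the scatter, so 2-chlorophenyl and 3-chloro-4-methylphenyl cannot be told apart at this place. The step of a 1.6-fold higher number from compound 3 to compound 4 (0.20 log units; within the scatter) also stays within the scatter, which leaves 2-chlorophenyl and 4-methoxyphenyl unseparated as well. Chloro in place of hydrogen on an aromatic carbon gives the step of a 1.9-fold higher number from compound 1 to compound 4 (0.29 log units; within the scatter), again within the scatter, whereas the step of a 2.1-fold higher number from compound 1 to compound 2 (0.32 log units; beyond the scatter) lies beyond it and is the only change at this place that separates two compounds, and then only modestly.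

Nothing available accounts for how close these numbers lie, as no independent evidence bears on this result. From the compounds shown here alone, it remains open whether a ring carrying an amine or a carboxylic acid on the amide-type nitrogen, or a longer chain in place of the ring, would shift the number further than any of these steps, and in which direction.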